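This account rests on a few compounds, and the source may have more. Where it says the series, first, only, none or still open, it means among the compounds named here.

Compound 1 `CC(C)=CCn1c(CN2CCN(C(=O)C3CC3)CC2)nc2ccccc21` gives 74.3% in an assay on isolated protein for inhibition of aldehyde dehydrogenase 1A1 (Homo sapiens), read by spectrophotometry, tested at 10 uM; on this read-out lower numbers stand for less inhibition and higher numbers for more inhibition at the one concentration tested (going by the name of the read-out). Compound 2 `Cc1ccc(Cn2c(CN3CCN(C(=O)C4CC4)CC3)nc3ccccc32)cc1` gives 51.5%, and compound 3 `O=C(C1CC1)N1CCN(Cc2nc3ccccc3n2Cc2ccc(Cl)cc2)CC1` gives 56.6%, the second highest of the three numbers. The steps of a number 17.7 percentage points lower from compound 1 to compound 3 (beyond the scatter) and a number 5.1 percentage points higher from compound 2 to compound 3 (within the scatter) place it. Compound 4 `O=C(C1CC1)N1CCN(Cc2nc3ccccc3n2Cc2cccc(Cl)c2)CC1` differs from compound 3 by 3-chlorophenyl in place of 4-chlorophenyl on a saturated chain carbon bound to an aromatic nitrogen. Within the data shown here, no measured step exchanges 4-chlorophenyl for 3-chlorophenyl; the steps of a number 22.8 percentage points lower from compound 1 to compound 2 (beyond the scatter) and a number 17.7 percentage points lower from compound 1 to compound 3 (beyond the scatter) each replace the whole group on that carbon, and the step of a number 5.1 percentage points higher from compound 2 to compound 3 (within the scatter) exchanges chloro for methyl. That last exchange is the nearest guide, so the step of a number 1.6 percentage points lower from compound 3 to compound 4 (within the scatter) is expected to stay within the scatter. Compound 4 is estimated at 55%, with a range of 40% to 70%.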

Compound 4, a percentage reported as inhibition, at one concentration (the size of the read-out at that concentration, not a potency): 71.6%
The estimate for compound 4 lay 16.6 percentage points below the measured number; the measured number lies above the stated range.
By their numbers in this assay, from the lowest: compounds 2 and 3 (each within the scatter of the next); then compounds 4 and 1 (each within the scatter of the next).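

On the saturated chain carbon bound to an aromatic nitrogen, the place of the chloro on the phenyl ring counts in this assay: the change from 4-chlorophenyl to 3-chlorophenyl gives a number 15 percentage points higher from compound 3 to compound 4 (beyond the scatter), and the change from 4-methylphenyl to 3-chlorophenyl gives a number 20.1 percentage points higher from compound 2 to compound 4 (beyond the scatter). With a number 2.7 percentage points lower from compound 1 to compound 4 (within the scatter), the drop seen on leaving 2-methylprop-1-en-1-yl for compounds 2 and 3 does not extend to compound 4, so it does not hold for every substituted phenyl here. No available evidence bears on this difference between the two chlorophenyl groups.

As far as these compounds go, it remains open whether the gap between the chlorophenyl isomers persists with methyl in place of chloro. Also open, from the compounds shown here alone, is how an amine, a carboxylic acid or a longer chain would read on this carbon.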